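A few compounds are considered here, and "the series" means these few. Any claim that something is new, unique, unknown or untested is made for them only; others in the source may bear on it.

Compound 1, `O=S(=O)(Nc1ccc(F)c(C#Cc2cnc3ccnn3c2)c1F)c1cccnc1`: 10000 nM
Compound 2, `COc1n[nH]c2ncc(C#Cc3c(F)ccc(NS(=O)(=O)c4cccnc4)c3F)cc12`: 1280 nM

Both were tested in a functional assay on HCT-116 cells (Homo sapiens) for antiproliferative activity, read by MTT assay, with a stated time of 68 h; a lower number here means a stronger inhibitor, a higher number a weaker inhibitor. Going by the values given here, on these two numbers compound 2 stands lowest, and the only other entry is compound 1, whose number is higher by a gap beyond the usual scatter. Compound 3, `O=S(=O)(Nc1ccc(F)c(C#Cc2cnc3[nH]nc(-c4cccc(Cl)c4)c3c2)c1F)c1cccnc1`, is not yet measured; it differs from compound 2 in one place: 3-chlorophenyl in place of methoxy on an aromatic carbon. Among the compounds with values here, no measured pair shows this change, so the size of the step is open. The expected step of a 2.6-fold lower number from compound 2 to compound 3 (0.41 log units; beyond the scatter) is a modest decrease in the number, possibly beyond the scatter. Compound 3 is estimated at 500 nM, with a likely range from 120 nM to 2500 nM.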

Compound 3, half-maximal inhibitory concentration: > 10000 nM
Compound 3: no number, only a limit (the forecaster's own chance of this, stated with the estimate: 5%); at least 20-fold (1.30 log units) between middle value and limit.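

In this assay compound 3 gives > 10000 nM, which is a limit of the assay and not a number. Placing 3-chlorophenyl instead of methoxy on this aromatic carbon gives an at least 7.8-fold higher number from compound 2 to compound 3 (0.89 log units; beyond the scatter), the first sign that this position responds strongly to the group it carries. The full size of the loss cannot be read, because the result sits at a limit: the limit of > 10000 nM in this assay, at which 1 of the 3 values shown sits.

The compounds shown leave open whether the new ring, its chlorine or the departure of methoxy accounts for the loss. They also do not show how a plain phenyl, an amine or an ethoxy group would behave on the same carbon.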